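Methoxy on an imidazoline biaryl, judged from two limits

The source may report more compounds than this note shows. Statements on the series, on what has been measured and on what is new or still open speak of the compounds shown alone.

Measured so far:
compound 1, `CC(C)NC(=N)c1cccc(-c2cc3cc(C(=N)NC(C)C)ccc3o2)c1`, > 199000 nM
compound 2, `c1cc(-c2cc3ccc(C4=NCCN4)cc3o2)ccc1C1=NCCN1`, 4500 nM
compound 3, `COc1ccc(C(=N)NC(C)C)cc1-c1cc2cc(C(=N)NC(C)C)ccc2o1`, > 179000 nM

In an ADME assay on L6 cells (Rattus norvegicus) for cytotoxicity (a lower number here means a stronger inhibitor, a higher number a weaker inhibitor), compound 1 gives > 199000 nM, which is a limit of the assay and not a number. Compound 3 likewise gives > 179000 nM in this assay, again a limit. Within the data shown here, compound 2 gives 4500 nM, the only number among the three. Compound 1 and compound 3 differ in one place: methoxy in place of hydrogen on an aromatic carbon. The step that the two limits leave unreadable from compound 1 to compound 3 cannot be read because the limit of > 179000 nM in this assay, at which 1 of the 3 values shown sits, and the limit of > 199000 nM in this assay, at which 1 of the 3 values shown sits, cap both ends of it. The difference between the core of compound 1 and the core of compound 2 is not broken down here.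

Compound 4, `COc1cc(C2=NCCN2)ccc1-c1cc2ccc(C3=NCCN3)cc2o1`, is not yet measured. It is made from compound 2 by methoxy in place of hydrogen on an aromatic carbon. This is the same kind of change as that from compound 1 to compound 3, but the surroundings differ: in compound 3 the new group is ortho to a large group and para to a group of 6 heavy atoms, whereas in compound 4 it is ortho to a large group and meta to a group of 5 heavy atoms. Among the measured compounds shown here, the measured pair gives no size for the step, so only a modest step is expected from compound 2 to compound 4, a 1.2-fold higher number from compound 2 to compound 4 (0.09 log units; within the scatter), in this assay. Compound 4 is therefore estimated at 5500 nM, between 1500 nM and 25000 nM.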

Compound 4, half-maximal inhibitory concentration: 4400 nM
For compound 4 the middle estimate is 1.3-fold (0.10 log units) above the measured one, and the stated range covers the measured number.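

In this assay, methoxy in place of hydrogen on an aromatic carbon gives a 1.0-fold lower number from compound 2 to compound 4 (0.01 log units; within the scatter), so on this core the two compounds cannot be told apart. Among these compounds, the same change on the other core gives no step that can be read, because an end of that pair is a limit of the assay and not a number: the limit of > 179000 nM in this assay, at which 1 of the 4 values shown sits. Whether the change carries from one core to the other therefore remains unshown: one core gives a readable step and the other gives none to set beside it, so nothing says whether the two steps agree in size, and a single pair on one core, with the methoxy ortho to a large group and meta to a group of 5 heavy atoms, supports no rule for the series.

The compounds shown leave open what a group other than methoxy at this place, such as an amine, a carboxylic acid or a longer chain, would do to the number on the core of compound 2. They also leave open how methoxy would read at another place on that ring, and how any change on the core of compound 1 would read in a range where the assay gives a number.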